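Methyl for Fluoro at the Edge of the Assay Range

This account rests on a few compounds, and the source may have more. Where it says the series, first, only, none or still open, it means among the compounds named here.

Compound 1 `CCS[C@@H]1[C@H](SCC)[C@@H](Cn2cc(-c3ccc(F)cc3)nn2)O[C@H]1n1ccc(=O)[nH]c1=O`: 72400 nM
Compound 2 `CCS[C@@H]1[C@H](SCC)[C@@H](Cn2cc(-c3ccccc3C(F)(F)F)nn2)O[C@H]1n1ccc(=O)[nH]c1=O`: 81100 nM
Compound 3 `CCS[C@@H]1[C@H](SCC)[C@@H](Cn2cc(-c3ccc(F)cc3)nn2)O[C@H]1n1cc(C)c(=O)[nH]c1=O`: a limit of the assay, >= 100000 nM

In a functional assay on LAC cells (Homo sapiens) for cytotoxicity, read by MTT assay, with a stated time of 72 h (a higher number here means that more compound is needed for the effect, a lower number that less compound is needed), compound 1 gives 72400 nM and compound 2 gives 81100 nM. For compound 3 the figure >= 100000 nM is a limit of the assay rather than a number (the limit of >= 100000 nM in this assay, at which 1 of the 3 values shown sits). The two measured steps, a 1.1-fold higher number from compound 1 to compound 2 (0.05 log units; within the scatter) and an at least 1.3-fold higher number from compound 1 to compound 3 (0.14 log units; that floor lies within the scatter), both stay within the scatter, so compound 3 stands at the assay limit with nothing beyond the scatter separating it from compound 1. Compound 4 `CCS[C@@H]1[C@H](SCC)[C@@H](Cn2cc(-c3ccc(C)cc3)nn2)O[C@H]1n1cc(C)c(=O)[nH]c1=O` differs from compound 3 by methyl in place of fluoro on an aromatic carbon. Among the compounds with values here, no measured step covers this exchange, and the two that exist moved little, so the expected step that the limit leaves unreadable from compound 3 to compound 4 is none beyond the scatter, most likely ending at the limit again. Compound 4 is estimated at 120000 nM, within 55000 nM to 300000 nM.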

Compound 4, half-maximal effective concentration: >= 100000 nM
Compound 4 ended at the assay's limit; the forecaster's own chance of this, stated with the estimate: 70%; the middle value is on the limit's open side.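

Within the data shown here, compound 3 and compound 4 both sit at a limit of this assay, so no step between them can be read: the limit of >= 100000 nM in this assay, at which 2 of the 4 values shown sit. Going by these compounds, whether methyl in place of fluoro shifts the response at all stays open.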